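The compounds below may be only part of what the source reports. "The series", "measured", "known", "first", "only" and "open" are said of these compounds alone.

Measured so far:
Compound 1 `CC(C)=CCC1Cc2c(O)cc(=O)n(CCCO)c2CC1(C)C`: 0%
Compound 2 `CCOc1cc(=O)n(CCCO)c2c1CC(CC=C(C)C)C(C)(C)C2`: 16.6%
Compound 3 `CCOc1cc(=O)n(CCCO)c2c1CC(C/C=C(\C)CCC=C(C)C)C(C)(C)C2`: 0.8%

Three compounds sharing one core were tested in a functional assay on PANC-1 cells (Homo sapiens) for inhibition, read by MTT assay, with a stated time of 24 h, tested at 10 uM; a lower number here means less inhibition, a higher number more inhibition at the concentration tested (going by the name of the read-out). Compound 1 gives 0%, compound 2 gives 16.6% and compound 3 gives 0.8%. Compound 3 stands second of the three; it lies within the scatter of compound 1 and beyond the scatter below compound 2. Two single-place steps are shown. The step of a number 16.6 percentage points higher from compound 1 to compound 2 (beyond the scatter) follows ethyl in place of hydrogen on an oxygen on an aromatic ring, and the step of a number 15.8 percentage points lower from compound 2 to compound 3 (beyond the scatter) follows 3-methylbut-2-en-1-yl in place of hydrogen on a saturated chain carbon bound to a double-bonded chain carbon.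

Compound 4 `CC(C)=CCC/C(C)=C/CC1Cc2c(OC(=O)Nc3ccc(Cl)cc3)cc(=O)n(CCCO)c2CC1(C)C` is not yet measured. It differs from compound 3 in one place: (4-chlorophenyl)carbamoyl in place of ethyl on an oxygen on an aromatic ring. Going by the values given here, only the step from compound 1 to compound 2 touches the same oxygen, and there a small group entering raised the read-out modestly; no measured step exchanges ethyl for a larger group, so the direction of this change is not settled by the data. Compound 4 is therefore expected to move by a number 11.2 percentage points higher from compound 3 to compound 4 (beyond the scatter), a modest rise at most, and its value in this assay is estimated at 12%, within 0% to 35%.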

Compound 4, a percentage reported as inhibition, at one concentration (the size of the read-out at that concentration, not a potency): 4.3%
Compound 4: the middle estimate sits 7.7 percentage points above what was measured, and the stated range covers the measured number.
By their numbers in this assay, from the lowest: compounds 1, 3 and 4 (each within the scatter of the next); then compound 2.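

In this assay, the oxygen on the aromatic ring takes a far larger group than ethyl, one that brings a six-membered aromatic ring, a chlorine and an amide hydrogen, and the read-out shows a number 3.5 percentage points higher from compound 3 to compound 4 (within the scatter). The earlier compounds shown here showed only that ethyl entering at this oxygen goes with a rise on the shorter 3-methylbut-2-en-1-yl compound; this result adds that, on the longer chain of compound 3, exchanging ethyl for (4-chlorophenyl)carbamoyl neither raises nor lowers the read-out beyond the scatter, so the change gives no recovery of the level seen for compound 2 at 16.6% in this assay. Nothing measured here on these groups accounts for this result.

Going by these compounds alone, because both compounds in this step sit low in the range, it remains open whether the same exchange would matter on the shorter chain of compound 2, the only compound that stands beyond the scatter of its neighbours. Also open, on these data alone, is how this oxygen would respond to a propyl group, a phenylcarbamoyl group without the chlorine, or a group carrying an amine or a carboxylic acid.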